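This account rests on a few compounds, and the source may have more. Where it says the series, first, only, none or still open, it means among the compounds named here.

Working notes on the series.

Of the compounds shown here, two have been measured in a functional assay on Jurkat cells (Homo sapiens) for antiproliferative activity, read by MTT assay, with a stated time of 72 h; a lower number here means a stronger inhibitor, a higher number a weaker inhibitor. Compound 1 `O=C1C[C@H]2O[C@H]([C@H](O)c3ccccc3)[C@H](O)[C@H]2O1` gives 32500 nM in this assay. For the measured compounds named here, compound 2 `O=C1C[C@H]2O[C@H](Cc3ccccc3)[C@H](O)[C@H]2O1` gives 2520 nM in this assay, the lowest number of the two; the only measured step, a 13-fold lower number from compound 1 to compound 2 (1.11 log units; beyond the scatter), separates it from compound 1.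

The next compound is compound 3 `Cc1ccccc1[C@H](c1ccccc1)[C@H]1O[C@@H]2CC(=O)O[C@@H]2[C@H]1O`. Its change from compound 2 is 2-methylphenyl in place of hydrogen on a saturated chain carbon bound to an aromatic carbon and a saturated ring carbon. Going by the values given here, no measured step bears directly on this change: the one step on hand, a 13-fold lower number from compound 1 to compound 2 (1.11 log units; beyond the scatter), concerns a hydroxy leaving the same position and says nothing about an aromatic ring entering it. What remains is that compound 2, with a hydrogen at this position, stands lowest of the two numbers, and compound 3 keeps that hydrogen count reduced by the entering 2-methylphenyl. Without a relevant step, a large move in either direction is not expected in this assay; the estimate is centred a little below compound 2 with a wide range. Compound 3 is therefore expected to give 1500 nM, between 400 nM and 6000 nM, an expected step of a 1.7-fold lower number from compound 2 to compound 3 (0.23 log units; within the scatter).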

Compound 3, half-maximal inhibitory concentration: 21400 nM
Compound 3: the middle estimate sits 14-fold (1.15 log units) below what was measured, and the stated range ends below it.
By their numbers in this assay, from the lowest: compound 2; then compounds 3 and 1 (each within the scatter of the next).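

In this assay, the saturated chain carbon bound to an aromatic carbon and a saturated ring carbon does not accept 2-methylphenyl in place of hydrogen without a cost: the result is an 8.5-fold higher number from compound 2 to compound 3 (0.93 log units; beyond the scatter). Replacing hydroxy with 2-methylphenyl at the same carbon gives a 1.5-fold lower number from compound 1 to compound 3 (0.18 log units; within the scatter), so these two groups cannot be told apart here, and among the three compounds only compound 2, with hydrogen at this carbon, stands clearly apart from the others. No supporting data on hand explain these steps.

The compounds shown do not separate the effect of the entering aromatic ring from that of its methyl group, and a plain phenyl in place of the 2-methylphenyl would address this. On these data alone, it also remains open how a methyl, a fluorine, an amine or a longer alkyl chain at this carbon would compare with the hydrogen of compound 2.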